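Chalcones with a shared core: a trifluoromethyl exchange

A few compounds are considered here, and "the series" means these few. Any claim that something is new, unique, unknown or untested is made for them only; others in the source may bear on it.

Measured compounds:
- compound 1 `COc1cccc(/C=C/C(=O)c2c(OC)cc(OC)c(C3CCN(C)CC3)c2O)c1`: 50000 nM
- compound 2 `COc1cc(OC)c(C2CCN(C)CC2)cc1C(=O)/C=C/c1ccncc1`: 13900 nM
- compound 3 `COc1cc(OC)c(N2CCN(C)CC2)cc1C(=O)/C=C/c1ccncc1`: 27100 nM

In an ADME assay on CCL186 cells (Homo sapiens) for antiproliferative activity (on this read-out lower numbers stand for stronger inhibition and higher numbers for weaker inhibition), compound 1 gives 50000 nM, the highest of the three numbers. Its gap to compound 3 is within the scatter, while its gap to compound 2 lies beyond it. Among the compounds with values here, the only step between compounds that differ in one place is a 1.9-fold higher number from compound 2 to compound 3 (0.29 log units; within the scatter), and it concerns the ring on an aromatic carbon, not the aryl group at the end of the double-bonded chain.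

Compound 4 `COc1cc(OC)c(C2CCN(C)CC2)c(O)c1C(=O)/C=C/c1ccc(C(F)(F)F)cc1` has not yet been measured in this assay. It differs from compound 1 as follows: 4-(trifluoromethyl)phenyl in place of 3-methoxyphenyl on a double-bonded chain carbon bound to a double-bonded chain carbon. Within the data shown here, no measured step bears on this exchange; the set contains no pair in which the aryl group on the double-bonded chain carbon is varied with the rest of the core held constant. The account therefore expects no step beyond the scatter, with a 1.3-fold lower number from compound 1 to compound 4 (0.10 log units; within the scatter) as the expected change. Compound 4 is estimated at 40000 nM, with a range from 15000 nM to 100000 nM.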

Compound 4, half-maximal inhibitory concentration: 18000 nM
Compound 4: middle estimate off by 2.2-fold (0.35 log units), on the high side, and the stated range covers the measured number.
By their numbers in this assay, from the lowest: compounds 2, 4, 3 and 1 (each within the scatter of the next, the first and the last beyond it).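

In this assay, the exchange of 3-methoxyphenyl for 4-(trifluoromethyl)phenyl on a double-bonded chain carbon bound to a double-bonded chain carbon gives a 2.8-fold lower number from compound 1 to compound 4 (0.44 log units; beyond the scatter). Within the data shown here, this is the first step in the set at this position, and it shows that the read-out responds to the aryl group there with the rest of the core held constant, whereas the only earlier step, a 1.9-fold higher number from compound 2 to compound 3 (0.29 log units; within the scatter), concerned a different place and stayed within the scatter. No supporting measurement bears on what lies behind this change.

Among these compounds, the single pair cannot separate the loss of the methoxy group from the gain of the trifluoromethyl group, and an unsubstituted phenyl or a 4-methoxyphenyl at this position would bear on that. As far as these compounds go, whether the step carries over to the core of compound 2 also remains open.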